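The source may hold more compounds than are shown below. What is called first, only, known or untested is meant among the compounds shown, and "the series" means these compounds.

Of the compounds shown here, three have been measured in an ADME assay on microsomes from liver (Rattus norvegicus) for metabolic stability, read by LC-MS, in the presence of a further agent that is not named here; a lower number here means slower removal, a higher number faster removal of the compound. Compound 1 `Cc1ncc(C)n2nc(-c3ccn4cc(-c5ccc(Br)cc5)nc4n3)nc12` gives 15 mL.min-1.g-1, compound 3 `Cc1ncc(C)n2nc(-c3ccc4nc(-c5ccccc5)[nH]c4c3)nc12` gives 27.4 mL.min-1.g-1, and compound 2 `Cc1ncc(C)n2nc(-c3ccn4cc(-c5ccccc5)nc4n3)nc12` gives 5.6 mL.min-1.g-1. Compound 2 therefore has the lowest number of the three, and the other two lie beyond the scatter above it.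

Compound 4 `Cc1ncc(C)n2nc(-c3ccn4cc(-c5ccc(F)cc5)nc4n3)nc12` keeps the structure of compound 2 with a single change: fluoro in place of hydrogen on an aromatic carbon. This places fluoro in place of hydrogen on an aromatic carbon, para to a large group, turning phenyl into 4-fluorophenyl.

Within the data shown here, only one measured step bears on this change: a 2.7-fold lower number from compound 1 to compound 2 (0.43 log units; beyond the scatter), with hydrogen in place of bromo. Read in reverse, it links bromo on that ring to a higher number. Among the measured compounds shown here, no measured compound shows what fluoro does, so this single step gives only a tentative direction, and a smaller rise seems the cautious expectation. The expected change is a 1.3-fold higher number from compound 2 to compound 4 (0.13 log units; within the scatter), which would stay within the scatter. For compound 4, the estimated value is 7.5 mL.min-1.g-1, with an expected range from 4 mL.min-1.g-1 to 14 mL.min-1.g-1.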

Compound 4, intrinsic clearance in microsomes: 3.1 mL.min-1.g-1
Estimate against measurement, compound 4: 2.4-fold (0.38 log units) above; the whole stated range lies above it.
By their numbers in this assay, from the lowest: compounds 4 and 2 (each within the scatter of the next); then compounds 1 and 3 (each within the scatter of the next).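

In this assay, fluoro in place of hydrogen, para to a large group, gives a 1.8-fold lower number from compound 2 to compound 4 (0.26 log units; within the scatter), so compounds 2 and 4 cannot be told apart, and the higher number seen with bromo does not carry over to fluoro. The direct comparison of the two halogens at this one position gives a 4.8-fold lower number from compound 1 to compound 4 (0.68 log units; beyond the scatter), which shows that the choice of halogen matters here and that bromo, not halogen as such, goes with the higher number. Nothing measured here explains why bromo and fluoro part ways.

As far as these compounds go, only hydrogen, fluoro and bromo have been seen at this position, so it remains open whether chloro, methoxy or an amine would stay close to hydrogen and fluoro or would move towards bromo. From the compounds shown here alone, it is also open whether 4-fluorophenyl would give a similar result on the core of compound 3.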